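The source may hold more compounds than are shown below. What is called first, only, known or untested is meant among the compounds shown, and "the series" means these compounds.

Series notes. Compound 1 `CCCCCCCCC/C=C1\CC(CO)(COC(=O)c2cn(C)c3ccccc23)OC1=O` gives 63.3 nM in an assay for displacement of a labelled ligand from RAS guanyl-releasing protein 1 (Homo sapiens), read by scintillation counting, in the presence of a further agent that is not named here; on this read-out lower numbers stand for stronger inhibition and higher numbers for weaker inhibition. For the measured compounds named here, compound 2 `CCCC(/C=C1\CC(CO)(COC(=O)c2cn(C)c3ccccc23)OC1=O)CCC` gives 133 nM in this assay, the higher of the two numbers measured so far, and the step of a 2.1-fold higher number from compound 1 to compound 2 (0.32 log units; beyond the scatter) is the only one recorded in the set. Compound 3 `CC(C)C(C/C=C1\CC(CO)(COC(=O)c2cn(C)c3ccccc23)OC1=O)C(C)C` has not yet been measured. It differs from compound 2 by 2-isopropyl-3-methylbutyl in place of 1-propylbutyl on a double-bonded chain carbon bound to a double-bonded ring carbon, so the branching of the chain attached at the double-bonded chain carbon is kept and carried further. Going by the values given here, the only measured step that bears on this change is a 2.1-fold higher number from compound 1 to compound 2 (0.32 log units; beyond the scatter), where a branched chain in place of a straight one moved the number toward weaker inhibition by a modest amount. With a single step to go on, a further branched chain is expected to leave the number in this assay no lower than that of compound 2, and most likely somewhat higher, though the support is thin. The step expected here is a 1.5-fold higher number from compound 2 to compound 3 (0.18 log units; within the scatter). For compound 3 the expected value in this assay is 200 nM, ranging from 80 nM to 500 nM.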

Compound 3, inhibition constant: 31.3 nM
For compound 3 the middle estimate is 6.4-fold (0.81 log units) above the measured one; the measured number lies below the stated range.
By their numbers in this assay, from the lowest: compound 3; then compound 1; then compound 2.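

In this assay, branching of the chain on a double-bonded chain carbon bound to a double-bonded ring carbon does not act in a single direction: 2-isopropyl-3-methylbutyl in place of 1-propylbutyl gives a 4.2-fold lower number from compound 2 to compound 3 (0.63 log units; beyond the scatter), the opposite direction to the earlier step, a 2.1-fold higher number from compound 1 to compound 2 (0.32 log units; beyond the scatter). A branched chain can also give stronger inhibition than the straight chain, as 1-isopropyl-2-methylpropyl in place of octyl gives a 2.0-fold lower number from compound 1 to compound 3 (0.31 log units; beyond the scatter), so branching as such carries no penalty across these three compounds, although compound 2 goes against any rule that branching helps, and compound 3 is the strongest of the three, with both of its steps beyond the scatter. Nothing available accounts for the reversal, so the shape of the chain can be linked to the read-out only as an observation.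

As far as these compounds go, with three compounds, it remains open whether the lower number in compound 3 belongs to this particular branching pattern or would also appear with a tert-butyl end group or a cyclohexyl ring on the chain. From the compounds shown here alone, it is equally open how a terminal hydroxyl or an amine on the chain would fit the order seen here.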